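The source may hold more compounds than are shown below. What is called first, only, known or untested is meant among the compounds shown, and "the series" means these compounds.

Measured so far in a functional assay on NPC-TW01 cells (Homo sapiens) for inhibition, read by MTT assay, with a stated time of 72 h; on this read-out lower numbers stand for stronger inhibition of growth and higher numbers for weaker inhibition of growth:
- compound 1 `COC(=O)c1nc(C)n(-c2ccccc2)n1`: > 100000 nM, a limit of the assay
- compound 2 `COC(=O)c1nc(C(C)C)n(-c2ccc(F)cc2)n1`: > 100000 nM, a limit of the assay

Compound 2 stands only at a limit in this assay. The other value shown is a limit as well: the limit of > 100000 nM in this assay, at which 2 of the 2 values shown sit. Among the compounds with values here, no step between measured compounds is available.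

Compound 3 `COC(=O)c1nc(-c2ccc[nH]2)n(-c2ccc(F)cc2)n1` carries 1H-pyrrol-2-yl in place of isopropyl on an aromatic carbon, 1H-pyrrol-2-yl in place of isopropyl on an aromatic carbon. With both measured values sitting at the limit, the expected step of an at least 1.2-fold lower number from compound 2 to compound 3 (0.09 log units; that floor lies within the scatter) is judged small, if any, and a further limit is the likely outcome. Compound 3 is estimated at 80000 nM, within 20000 nM to 300000 nM.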

Compound 3, concentration for 50% growth inhibition: 9580 nM
The estimate for compound 3 lay 8.4-fold (0.92 log units) above the measured number; measured number below the stated range.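

In this assay this position on the shared core proves able to carry growth inhibition: 1H-pyrrol-2-yl in place of isopropyl on an aromatic carbon gives an at least 10-fold lower number from compound 2 to compound 3 (1.01 log units; beyond the scatter) on this read-out. Compound 3 reaches 9580 nM as the only number shown that is not a limit. Compound 2 stands at a limit, so the step is a bound and not a measured size: the limit of > 100000 nM in this assay, at which 2 of the 3 values shown sit.

Furan-2-yl or 1-methyl-1H-pyrrol-2-yl at this position would show whether the change follows the aromatic ring or its hydrogen-bond donor. On these data alone, whether a carboxylic acid in place of the methoxycarbonyl group keeps the inhibition also stays open.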